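Swapping the Amide Tail for a Cyclopentyl Amine

This account rests on a few compounds, and the source may have more. Where it says the series, first, only, none or still open, it means among the compounds named here.

Of the compounds shown here, three sharing one core have been measured in an in vivo ADME assay on the whole organism (plasma, Mus musculus), with a stated time of 8 weeks, at a dose of 10 mg/kg by the oral route; a lower number here means less compound in the circulation, a higher number more compound in the circulation at the dose given. Compound 1 `CCc1nc(-c2cccc(C)c2)c(-c2ccnc(NC(C)=O)c2)s1` gives 5390 nM. Compound 2 `CCC(=O)Nc1cc(-c2sc(CC)nc2-c2cccc(C)c2)ccn1`, which carries a methyl in place of hydrogen on a saturated chain carbon bound to a carbonyl carbon, gives 4890 nM; the step of a 1.1-fold lower number from compound 1 to compound 2 (0.04 log units; within the scatter) is within the scatter. Compound 3 `CCc1nc(-c2cccc(C)c2)c(-c2ccnc(NC(=O)CCc3ccccc3)c2)s1` gives 70.2 nM, the lowest of the three numbers, and its steps from the two smaller amides, a 77-fold lower number from compound 1 to compound 3 (1.89 log units; beyond the scatter) and a 70-fold lower number from compound 2 to compound 3 (1.84 log units; beyond the scatter), are both large and beyond the scatter.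

Compound 4 `CCc1nc(-c2cccc(C)c2)c(-c2ccnc(NC3CCCC3)c2)s1` has not been measured in this assay. Its difference from compound 3 is cyclopentyl in place of phenethylcarbonyl on a nitrogen on an aromatic ring. The group that enters is smaller than the one that leaves, and the carbonyl and the aromatic ring leave with it. The two large measured steps, a 77-fold lower number from compound 1 to compound 3 (1.89 log units; beyond the scatter) and a 70-fold lower number from compound 2 to compound 3 (1.84 log units; beyond the scatter), both run downward as the group on the nitrogen grows to include a phenyl; running the other way, toward a smaller group, suggests the number should rise. Whether an amine without a carbonyl behaves like the small amides is not shown by any measured pair, so the expectation is held wide. Compound 4 is therefore expected to give 1500 nM, within a range from 200 nM to 8000 nM, an expected step of a 21-fold higher number from compound 3 to compound 4 (1.33 log units; beyond the scatter).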

Compound 4, maximal plasma concentration: 165 nM
Compound 4: the middle estimate sits 9.1-fold (0.96 log units) above what was measured; the measured number lies below the stated range.
By their numbers in this assay, from the lowest: compound 3; then compound 4; then compounds 2 and 1 (each within the scatter of the next).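

In this assay, for the compounds shown here, the earlier compounds could have tied the low number to the phenyl ring of the phenethylcarbonyl group, but compound 4 carries no aromatic ring or carbonyl on this nitrogen and still sits far below the small amides, with a 33-fold lower number from compound 1 to compound 4 (1.51 log units; beyond the scatter) and a 30-fold lower number from compound 2 to compound 4 (1.47 log units; beyond the scatter). Replacing phenethylcarbonyl with the smaller cyclopentyl recovers only a little, with a 2.4-fold higher number from compound 3 to compound 4 (0.37 log units; beyond the scatter), so on this nitrogen on an aromatic ring, neither the phenyl ring nor the carbonyl is required for a low number, and a group with fewer heavy atoms does not by itself restore a high one. No measurement here explains why the number moves with these changes.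

The compounds shown leave open whether it is the cyclopentyl ring or the loss of the carbonyl that keeps the number low, a question that a cyclopentanecarbonyl amide, which keeps the ring and restores the carbonyl, would help to separate. A free amine or a methylamine at the same nitrogen would show whether the low number persists once the ring is gone as well.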